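A few compounds are considered here, and "the series" means these few. Any claim that something is new, unique, unknown or untested is made for them only; others in the source may bear on it.

Three compounds share one core. Compound 1 `COc1ccc(C(=O)Nc2ccccc2-c2nnn(-c3ccc(OC)cc3)n2)cc1` gives 305 nM in a functional assay on NCI-H460 cells (Homo sapiens) for positive allosteric modulation, read by MTT assay, with stated times of 2 h and 72 h, tested at 1 uM; on this read-out lower numbers stand for stronger inhibition and higher numbers for weaker inhibition. Compound 2 `COc1cccc(-n2nnc(-c3ccccc3NC(=O)c3ccc(N)cc3)n2)c1` gives 217 nM, and compound 3 `COc1cccc(-n2nnc(-c3ccccc3NC(=O)c3ccc(N=[N+]=[N-])cc3)n2)c1` gives 558 nM. Among these three, compound 3 carries the highest number: its gap to compound 1 lies within the scatter, while the one measured step reads a 2.6-fold higher number from compound 2 to compound 3 (0.41 log units; beyond the scatter). Compound 4 `COc1cccc(-n2nnc(-c3ccccc3NC(=O)Nc3ccc(N)cc3)n2)c1` is compound 3 altered at a single place: (4-aminophenyl)amino in place of 4-azidophenyl on a carbonyl carbon. That measured step is the only one that bears on this change, as it shows azido replacing amino; undoing that swap alone points to a lower number, yet the rest of the change has no measured parallel. Compound 4 is therefore expected to give about 250 nM, within 110 nM to 600 nM, an expected step of a 2.2-fold lower number from compound 3 to compound 4 (0.35 log units; beyond the scatter).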

Compound 4, half-maximal inhibitory concentration: 228 nM
Compound 4: the middle estimate sits 1.1-fold (0.04 log units) above what was measured, and the stated range covers the measured number.
By their numbers in this assay, from the lowest: compounds 2, 4, 1 and 3 (each within the scatter of the next, the first and the last beyond it).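

Putting (4-aminophenyl)amino in place of 4-aminophenyl on the carbonyl carbon gives a 1.1-fold higher number from compound 2 to compound 4 (0.02 log units; within the scatter) in this assay, so adding this nitrogen link to the amide-type nitrogen and carbonyl causes no readable change. Measured against the azido compound, the same amino-bearing end gives a 2.4-fold lower number from compound 3 to compound 4 (0.39 log units; beyond the scatter) and this places compound 4 with compound 2 rather than with compound 3. Nothing at hand gives a cause for either step. As far as these compounds go, what a hydroxyl or a carboxylic acid in place of the amino group on this longer link would give remains open.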